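Coumarin amide series: anilino replacing isopropyl(methyl)amino on the ether chain

A few compounds are considered here, and "the series" means these few. Any claim that something is new, unique, unknown or untested is made for them only; others in the source may bear on it.

Two compounds of this series have numbers in a functional assay on SK-BR-3 cells (Homo sapiens) for antiproliferative activity; a higher number here means a weaker inhibitor, a lower number a stronger inhibitor. Compound 1 `CC(C)=CCc1cc(C(=O)Nc2cc3ccc(OCC4CCN(C)C4)c(C)c3oc2=O)ccc1O` gives 920 nM. Compound 2 `CC(C)=CCc1cc(C(=O)Nc2cc3ccc(OCCCN(C)C(C)C)c(C)c3oc2=O)ccc1O` gives 570 nM. The only measured step, a 1.6-fold lower number from compound 1 to compound 2 (0.21 log units; within the scatter), lies within the scatter, so on the numbers shown compound 2 and compound 1 are not separated.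

Compound 3 `CC(C)=CCc1cc(C(=O)Nc2cc3ccc(OCCCNc4ccccc4)c(C)c3oc2=O)ccc1O` is not yet measured. It differs from compound 2 by anilino in place of isopropyl(methyl)amino on a saturated chain carbon, three bonds along the chain from an oxygen on an aromatic ring. Among the compounds with values here, the one measured step touches the same chain on the ether oxygen and was within the scatter, but it exchanged one saturated amine for another; no measured step covers the entry of anilino, so nothing in the data sets the size of this step.

Compound 3 is therefore estimated at 1400 nM in this assay, within 450 nM to 4500 nM. This means an expected step of a 2.5-fold higher number from compound 2 to compound 3 (0.39 log units; beyond the scatter), with the wide range reflecting the absence of a comparable measured step.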

Compound 3, half-maximal inhibitory concentration: > 50000 nM
Compound 3 was reported as a limit (the forecaster's own chance of this, stated with the estimate: 5%); middle value at least 35-fold (1.55 log units) away from the limit.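

Compound 3 is reported in this assay only as a limit and not as a number: the limit of > 50000 nM in this assay, at which 1 of the 3 values shown sits. The end of the ether chain is not indifferent to what sits there: the exchange of one saturated amine for another stayed within the scatter, whereas anilino in place of isopropyl(methyl)amino gives an at least 87-fold higher number from compound 2 to compound 3 (1.94 log units; beyond the scatter), and 2-anilinoethyl in place of 1-methylpyrrolidin-3-yl gives an at least 54-fold higher number from compound 1 to compound 3 (1.73 log units; beyond the scatter). The agreement between compound 1 and compound 2 therefore does not extend to anilino at this position.

Anilino differs from isopropyl(methyl)amino both in its six-membered aromatic ring and in its hydrogen-bond donor, so the compounds shown do not tell which of the two goes with the large step. An N-methylanilino or a benzylamino group at the chain end would begin to separate them.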